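The compounds below may be only part of what the source reports. "The series", "measured", "known", "first", "only" and "open" are said of these compounds alone.

Of the compounds shown here, three built on one shared core have been measured in a functional assay on CHO cells with adenosine receptor A1 (Homo sapiens) as the target, read by cAMP accumulation and immunoassay, with a stated time of 6 min, tested at 10 uM; a higher number here means a weaker effect of the compound at the concentration tested, a lower number a stronger effect. Compound 1 `Nc1scc(CN2CCN(c3cccc(Cl)c3Cl)CC2)c1C(=O)c1ccc(Cl)cc1` gives -77%. Compound 2 `Nc1scc(CN2CCN(c3ccc([N+](=O)[O-])cc3)CC2)c1C(=O)c1ccc(Cl)cc1` gives -17%. Compound 3 `Nc1scc(CN2CCN(C3CCCCCC3)CC2)c1C(=O)c1ccc(Cl)cc1` gives -25%. Compound 3 thus stands second highest of the three numbers, within the scatter of compound 2 and well apart from compound 1.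

Compound 4 `Nc1scc(CN2CCN(c3c(F)cc(F)cc3F)CC2)c1C(=O)c1ccc(Cl)cc1` differs from compound 3 in one place: 2,4,6-trifluorophenyl in place of cycloheptyl on an amine nitrogen in a ring. Among the measured compounds shown here, two measured steps bear on this exchange of an aromatic group for the cycloheptyl. The step of a number 52 percentage points higher from compound 1 to compound 3 (beyond the scatter) shows that replacing a 2,3-dichlorophenyl by cycloheptyl raised the number sharply, so the reverse exchange would lower it. The step of a number 8 percentage points lower from compound 2 to compound 3 (within the scatter) shows that exchanging 4-nitrophenyl for cycloheptyl changed nothing beyond the scatter. The two aryl groups themselves lie far apart, as a number 60 percentage points higher from compound 1 to compound 2 (beyond the scatter) shows, so the outcome for a third aryl group is uncertain. A step in the downward direction is expected for compound 4, of a size between those two cases, a number 20 percentage points lower from compound 3 to compound 4 (beyond the scatter). Compound 4 is therefore estimated to give -45% in this assay, with a range from -80% to -10%.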

Compound 4, a percentage reported as activity, at one concentration (the size of the read-out at that concentration, not a potency): -78%
The estimate for compound 4 lay 33 percentage points above the measured number, and the stated range covers the measured number.
By their numbers in this assay, from the lowest: compounds 4 and 1 (each within the scatter of the next); then compounds 3 and 2 (each within the scatter of the next).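

The exchange of cycloheptyl for 2,4,6-trifluorophenyl on the amine nitrogen in the ring gives a number 53 percentage points lower from compound 3 to compound 4 (beyond the scatter) in this assay, and the exchange of 4-nitrophenyl for the same group gives a number 61 percentage points lower from compound 2 to compound 4 (beyond the scatter) at this position, so a second halogen-bearing phenyl group now stands apart from both of those substituents, while compound 2 shows that a phenyl ring alone does not carry the number that far. Set against 2,3-dichlorophenyl, the new group gives a number 1 percentage points lower from compound 1 to compound 4 (within the scatter) and so shows that fluorine in place of chlorine, with a different number and placement of halogens on the phenyl ring, leaves the read-out unchanged for this pair. Nothing measured here accounts for the separation of these two halogen-bearing groups from the 4-nitrophenyl group.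

The compounds shown leave open whether a phenyl ring carrying a single fluorine or a single chlorine would stay with compound 1 and compound 4 or fall with compound 2. They also leave open where a methoxyphenyl or a benzyl group on the same nitrogen would stand, and how any of these compounds would compare across a range of concentrations rather than at the single one tested.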